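Alkyl chain lengthening on the triazole of an imidazoline series

The source may hold more compounds than are shown below. What is called first, only, known or untested is meant among the compounds shown, and "the series" means these compounds.

Notes on the series. Compound 1 `c1ccc(-c2nc[nH]n2)c(NCC2=NCCN2)c1` in an in vitro functional assay on cells (Fibroblast) for agonist activity at Alpha-1D adrenergic receptor (Homo sapiens) (on this read-out higher numbers stand for an effect only at larger amounts of compound and lower numbers for an effect already at smaller amounts), gives 3.98 nM. Going by the values given here, compound 2 `CCn1ncnc1-c1ccccc1NCC1=NCCN1` in this assay gives 126 nM, the higher of the two numbers so far, and its gap to compound 1 lies beyond the usual scatter. Compound 3 `CCCCn1ncnc1-c1ccccc1NCC1=NCCN1` is not yet measured; relative to compound 2 it carries ethyl in place of hydrogen on a saturated chain carbon, two bonds along the chain from an aromatic nitrogen. Among the compounds with values here, no pair of measured compounds differing in one place is available to size this step. Growing the chain further is expected to shift the number modestly upward, the estimated step being a 2.0-fold higher number from compound 2 to compound 3 (0.30 log units; within the scatter). For compound 3 the estimate in this assay is 250 nM, within 60 nM to 1200 nM.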

Compound 3, half-maximal effective concentration: 398 nM
The estimate for compound 3 lay 1.6-fold (0.20 log units) below the measured number; the measured number falls inside the stated range.
By their numbers in this assay, from the lowest: compound 1; then compound 2; then compound 3.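

Ethyl in place of hydrogen on a saturated chain carbon, two bonds along the chain from an aromatic nitrogen, gives a 3.2-fold higher number from compound 2 to compound 3 (0.50 log units; beyond the scatter) in this assay. Going by these compounds alone, this is the first sized step at this position, and it shows that the read-out responds to the ethyl to butyl change, with the larger number going with the longer chain. Nothing on hand gives a reason for this step.

Going by these compounds, a single step sets no trend, so the place of propyl or hexyl on this line remains open. So does the effect of a branched isopropyl group or of a chain ending in an amine.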